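A few compounds are considered here, and "the series" means these few. Any claim that something is new, unique, unknown or untested is made for them only; others in the source may bear on it.

Compound 1 `O=C(c1ccccn1)N1CCC(NS(=O)(=O)c2cc(S(=O)(=O)c3ccccc3)ccc2C(F)(F)F)CC1` gives 100000 nM
Compound 2 `O=C(O)c1cccc(S(=O)(=O)N2CCC(NS(=O)(=O)c3cc(S(=O)(=O)c4ccccc4)ccc3C(F)(F)F)CC2)c1` gives 12500 nM

In a physicochemical assay for solubility (on this read-out lower numbers stand for lower solubility and higher numbers for higher solubility), compound 2 sits at 12500 nM and holds the lower of the two numbers. Compound 3 `O=S(=O)(NC1CCN(S(=O)(=O)c2cccc(-c3nnn[nH]3)c2)CC1)c1cc(S(=O)(=O)c2ccccc2)ccc1C(F)(F)F` differs from it in one place (1H-tetrazol-5-yl in place of carboxy on an aromatic carbon) with 1H-tetrazol-5-yl in place of carboxy on an aromatic carbon. Among the measured compounds shown here, the one measured step is an 8.0-fold lower number from compound 1 to compound 2 (0.90 log units; beyond the scatter) and it exchanged a different group on an amine nitrogen in a ring, so it does not test this swap. No step beyond the scatter is therefore expected, in either direction. The expected step is a 1.0-fold lower number from compound 2 to compound 3 (0.02 log units; within the scatter) and it stays small. For compound 3 the estimate is 12000 nM with an expected range from 4000 nM to 40000 nM on this scale.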

Compound 3, solubility: 100000 nM
For compound 3 the middle estimate is 8.3-fold (0.92 log units) below the measured one; measured number above the stated range.
By their numbers in this assay, from the lowest: compound 2; then compounds 1 and 3 (each within the scatter of the next).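

In this assay, swapping the group on this aromatic carbon gives an 8.0-fold higher number from compound 2 to compound 3 (0.90 log units; beyond the scatter), a step beyond the scatter. The earlier pair did not test this position, and here carboxy and 1H-tetrazol-5-yl clearly do not behave alike, with the rest of the molecule unchanged. Nothing measured here explains the step. From the compounds shown here alone, it remains open how other groups on this carbon, such as an amine or a primary amide, would compare. Also open, going by these compounds, is whether the same swap gives a similar step on a different core.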